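Methoxy for Chloro on a Caffeate Anilide Ester

A few compounds are considered here, and "the series" means these few. Any claim that something is new, unique, unknown or untested is made for them only; others in the source may bear on it.

Measured compounds:
compound 1, `COCOc1cc(/C=C/C(=O)OCC(=O)NN2CCOCC2)ccc1OCc1ccccc1`, 32400 nM
compound 2, `O=C(COC(=O)/C=C/c1ccc(O)c(O)c1)Nc1ccc(Cl)cc1`, 99400 nM

Two compounds have numbers in a functional assay on K562 cells (Homo sapiens) for cytotoxicity, read by MTT assay, with a stated time of 72 h; a lower number here means a stronger inhibitor, a higher number a weaker inhibitor. Compound 1 gives 32400 nM. Compound 2 stands at the higher end of the two: in this assay compound 2 gives 99400 nM, a weaker result than compound 1 by a gap that lies beyond the scatter. Going by the values given here, no other pair is measured, so no single-point step is known.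

Compound 3, `COc1ccc(NC(=O)COC(=O)/C=C/c2ccc(O)c(O)c2)cc1`, is not yet measured. It differs from compound 2 in one place: methoxy in place of chloro on an aromatic carbon. Nothing measured here tells how this exchange moves the number in this assay, so the expected step is small, and a move of no more than the scatter in either direction is the expectation, with a slight lean toward a weaker result. On that basis compound 3 is estimated at 110000 nM, within the range 40000 nM to 300000 nM; the step from compound 2 is expected to be a 1.1-fold higher number from compound 2 to compound 3 (0.04 log units; within the scatter).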

Compound 3, half-maximal inhibitory concentration: 79100 nM
Estimate against measurement, compound 3: 1.4-fold (0.14 log units) above, within the range that was stated.
By their numbers in this assay, from the lowest: compound 1; then compounds 3 and 2 (each within the scatter of the next).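

In this assay, going by these compounds alone, the exchange of chloro for methoxy on an aromatic carbon, para to a large group, supplies the first step in one place, and it reads a 1.3-fold lower number from compound 2 to compound 3 (0.10 log units; within the scatter) and so lies within the scatter. At this position, then, going from 4-chlorophenyl to 4-methoxyphenyl replaces a chlorine with a carbon and an oxygen and brings in one hydrogen-bond acceptor, with no change in the number that can be told from scatter. No data at hand explain this result.

The compounds shown leave open whether any group at this place can move the number beyond the scatter, for example an amine, a carboxylic acid or a longer chain such as butoxy. They also leave open whether the same exchange would give a similar step in another setting.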